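The compounds below may be only part of what the source reports. "The series", "measured", "known", "first", "only" and "open" are said of these compounds alone.

Measured so far:
Compound 1 `Cc1nnc(SCC(=O)c2ccc(Cl)cc2)n1N1C(=O)c2ccccc2C1=O`; in a functional assay on PC-3M cells (Homo sapiens) for cytotoxicity, read by MTT assay, with a stated time of 48 h (a higher number here means a weaker inhibitor, a lower number a stronger inhibitor), compound 1 gives > 200000 nM, which is a limit of the assay and not a number.
Compound 2 `CCc1nnc(SCC(=O)c2ccc(Cl)cc2)n1N1C(=O)c2ccccc2C1=O`; compound 2 gives > 200000 nM, again a limit.
Compound 3 `CCCc1nnc(SCC(=O)c2ccc(Cl)cc2)n1N1C(=O)c2ccccc2C1=O`; compound 3 gives > 200000 nM, also a limit.

The three measured compounds share one core and differ only in the short saturated chain attached to it. Compound 3 stands at the limit of the assay, and the two other values shown are that same limit (the limit of > 200000 nM in this assay, at which 3 of the 3 values shown sit). Because all three sit there, the step that the two limits leave unreadable from compound 1 to compound 2, the step that the two limits leave unreadable from compound 1 to compound 3 and the step that the two limits leave unreadable from compound 2 to compound 3 cannot be read: they might be nothing, or they might hide differences of any size.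

Compound 4 `CCCc1nnc(SCc2ccccc2Cl)n1N1C(=O)c2ccccc2C1=O` carries the change (2-chlorophenyl in place of (4-chlorophenyl)carbonyl on a saturated chain carbon bound to a sulfur). Going by the values given here, no measured step touches this part of the structure, so nothing in the data shows whether the change matters. Among the compounds with values here, the only guide is that every compound measured so far lies at the limit.

Compound 4 is therefore expected to give about 250000 nM, within a range of 40000 nM to 1500000 nM, and the expected step from compound 3 to compound 4 is a step that the limit leaves unreadable from compound 3 to compound 4, most likely again a limit.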

Compound 4, half-maximal inhibitory concentration: > 200000 nM
Compound 4 ended at the assay's limit (the forecaster's own chance of this, stated with the estimate: 70%); the middle value lies beyond the limit too.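

In this assay compound 4 gives > 200000 nM which is a limit and not a number. Going by these compounds alone, compound 3 also sits at a limit, so no step between these two compounds can be read: the limit of > 200000 nM in this assay, at which 4 of the 4 values shown sit. The compounds shown leave open how strongly any of them acts in this assay, and whether changing the short saturated chain or the group on the saturated chain carbon bound to a sulfur makes any difference.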